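Swapping a Dichlorophenyl Amide for a Pyridine Hydrazide

The source may hold more compounds than are shown below. What is called first, only, known or untested is meant among the compounds shown, and "the series" means these compounds.

Compound 1: `COc1ccc2nc(C)cc(OC(C)(C)C(=O)Nc3cc(C)cc(C)c3)c2c1` gives 20000 nM
Compound 2: `COc1ccc2nc(C)cc(OCC(=O)Nc3ccc(Cl)cc3Cl)c2c1` gives 20500 nM
Compound 3: `COc1ccc2nc(C)cc(OCC(=O)Nc3ccc(S(=O)(=O)Nc4cc(C)on4)cc3)c2c1` gives >= 381000 nM

In a physicochemical assay for solubility, in phosphate buffer, measured as kinetic solubility, with a stated time of 1 h, at pH 7.4 (a lower number here means a less soluble compound, a higher number a more soluble compound), compound 2 gives 20500 nM. Compound 1 gives 20000 nM, and the two numbers sit within the usual scatter of each other, so nothing separates them. For compound 3 the value >= 381000 nM is a limit of the assay, not a number, as the limit of >= 381000 nM in this assay, at which 1 of the 3 values shown sits, records.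

Compound 4 is `COc1ccc2nc(C)cc(OCC(=O)NNC(=O)c3ccncc3)c2c1`, not yet measured. Against compound 2 the change is ((pyridin-4-yl)carbonyl)amino in place of 2,4-dichlorophenyl on an amide-type nitrogen. The ((pyridin-4-yl)carbonyl)amino group brings a hydrogen-bond donor and two acceptors where the 2,4-dichlorophenyl had none, and the shared core stays unchanged. Among the measured compounds shown here, no measured pair isolates this change, so the expectation rests on the three values alone. The step from compound 2 to compound 4 is estimated as a clear rise, well beyond the scatter, an 8.8-fold higher number from compound 2 to compound 4 (0.94 log units; beyond the scatter). For compound 4 the expected solubility in this assay is 180000 nM, with a range from 50000 nM to 381000 nM, and a real chance that the assay again returns only a limit.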

Compound 4, solubility: >= 375000 nM
Compound 4: a limit, no number; the forecaster's own chance of this, stated with the estimate: 35%; at least 2.0-fold (0.31 log units) between middle value and limit.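

On this amide-type nitrogen, ((pyridin-4-yl)carbonyl)amino in place of 2,4-dichlorophenyl gives an at least 18-fold higher number from compound 2 to compound 4 (1.26 log units; beyond the scatter) in this assay, and this is the only measured pair shown that isolates a single change. That step gives only a lower bound on the full size of the change, because compound 4 ends at a limit of the assay and not at a number: the limit of >= 375000 nM in this assay, at which 1 of the 4 values shown sits. Compound 3, which carries a different group on the same nitrogen, also ends at a limit, so compound 3 and compound 4 cannot be put in order: the limit of >= 381000 nM in this assay, at which 1 of the 4 values shown sits.

Whether the ring nitrogen or the added carbonyl and amino part accounts for the step stays open. A benzoylamino group or a plain pyridin-4-yl group on the same nitrogen would separate these two parts.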